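This account rests on a few compounds, and the source may have more. Where it says the series, first, only, none or still open, it means among the compounds named here.

Working notes on the series. In a functional assay on KB cells (Homo sapiens) for inhibition, read by sulforhodamine B assay (a lower number here means a stronger inhibitor of growth, a higher number a weaker inhibitor of growth), compound 1 (`c1ccc(-c2ccc(-c3ccc(-c4nc5ccccc5[nH]4)cc3)cc2)cc1`) gives 39700 nM, the highest of the three measured numbers. Compound 2 (`Cc1ccc2[nH]c(-c3ccc(-c4ccc(-c5ccc(N(C)C)cc5)cc4)cc3)nc2c1`) gives 6240 nM and compound 3 (`COc1cc(-c2ccc(-c3ccc(-c4nc5cc(C)ccc5[nH]4)cc3)cc2)cc(OC)c1OC`) gives 2110 nM, both lower than compound 1 by more than the scatter. Within the data shown here, compound 2 and compound 3 each differ from compound 1 in more than one place, so no measured single-change step is available, and what separates their values from that of compound 1 cannot be assigned to any one change.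

The next compound is compound 4 (`FC(F)(F)c1ccc(-c2ccc(-c3ccc(-c4nc5ccccc5[nH]4)cc3)cc2)cc1`). Relative to compound 1, trifluoromethyl takes the place of hydrogen on an aromatic carbon of a six-membered aromatic ring of carbon only, para to a large group, turning phenyl into 4-(trifluoromethyl)phenyl: trifluoromethyl in place of hydrogen on an aromatic carbon.

Among the measured compounds shown here, the only guide is that the two more elaborated compounds sit lower, compound 2 at 6240 nM and compound 3 at 2110 nM, though neither isolates this change. A moderate move to a lower number is therefore expected, with a step within the scatter not excluded. The expected step is a 2.8-fold lower number from compound 1 to compound 4 (0.45 log units; beyond the scatter). For compound 4 the estimated value in this assay is 14000 nM, with an expected range of 4000 nM to 45000 nM.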

Compound 4, concentration for 50% growth inhibition: 47200 nM
For compound 4 the middle estimate is 3.4-fold (0.53 log units) below the measured one; measured number above the stated range.
By their numbers in this assay, from the lowest: compound 3; then compound 2; then compounds 1 and 4 (each within the scatter of the next).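

In this assay the series now has its first readable single change: a 1.2-fold higher number from compound 1 to compound 4 (0.08 log units; within the scatter) for trifluoromethyl in place of hydrogen on an aromatic carbon. At this place, on a six-membered aromatic ring of carbon only and para to a large group, turning phenyl into 4-(trifluoromethyl)phenyl brings in 4 heavy atoms and leaves the number within the scatter, so in this one case the position accepts the larger group with no readable change in growth inhibition. The steps to compound 2 and compound 3 cannot be read, as each differs from compound 1 in more than one place, and no measurement is at hand that would explain the result.

From the compounds shown here alone, whether a different group at this place, such as a carboxylic acid or a primary amide, would give a step beyond the scatter remains open. Also open, going by these compounds, is whether trifluoromethyl in place of hydrogen would give a similarly small step on the core of compound 3, since this single step on the core of compound 1 cannot settle that.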